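This account rests on a few compounds, and the source may have more. Where it says the series, first, only, none or still open, it means among the compounds named here.

Compound 1, `CCCCCCCCc1ccc(OCC(=O)Cn2nnc(SC)n2)cc1`, in an ADME assay on S9 fraction from liver (Rattus norvegicus) for metabolic stability, read by LC-MS, using NADPH, with a stated time of 30 min (on this read-out lower numbers stand for a less stable compound and higher numbers for a more stable compound), gives < 5%, which is a limit of the assay.
Compound 2, `CCCCCCCCc1ccc(OCC(=O)Cn2nnc(-c3ccc(Cl)cc3)n2)cc1`, gives 74%.
Compound 3, `CCCCCCCCc1ccc(OCC(=O)Cn2nnc(-c3ccccc3Cl)n2)cc1`, gives 28%.

Compound 2 stands highest of the two numbers; its nearest neighbour is compound 3, a number 46 percentage points lower from compound 2 to compound 3 (beyond the scatter). Compound 4, `CCCCCCCCc1ccc(OCC(=O)Cn2nnc(CCC(=O)O)n2)cc1`, differs from compound 2 in one place: 2-carboxyethyl in place of 4-chlorophenyl on an aromatic carbon. Of the measured steps, those at the same aromatic carbon bear on it, with a number at least 69 percentage points higher from compound 1 to compound 2 (beyond the scatter) and a number at least 23 percentage points higher from compound 1 to compound 3 (beyond the scatter); none of them exchanges the 4-chlorophenyl for a 2-carboxyethyl, so only the size of the swings at this position can be carried over. A step beyond the scatter, downward, is therefore the working assumption, and the step from compound 2 to compound 4 is expected to be a number 29 percentage points lower from compound 2 to compound 4 (beyond the scatter). Compound 4 is estimated at 45%, within 10% to 80%.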

Compound 4, percent of the compound remaining: < 5%
Compound 4 was reported as a limit (the forecaster's own chance of this, stated with the estimate: 10%); middle value at least 40 percentage points from the limit.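

In this assay, 2-carboxyethyl at this position brings a number at least 69 percentage points lower from compound 2 to compound 4 (beyond the scatter) and a number at least 23 percentage points lower from compound 3 to compound 4 (beyond the scatter). Compound 4 gives < 5%, which is a limit of the assay. Among the four compounds, a chlorophenyl group on this aromatic carbon goes with readable stability in compound 2 and compound 3, while two different groups without a ring, in compound 1 and compound 4, both end at the limit.

On these data alone, whether an unsubstituted phenyl, an amine or a longer alkyl chain here would stay above the limit remains open. The step between compound 1 and compound 4 cannot be read: the limit of < 5% in this assay, at which 2 of the 4 values shown sit.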